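Lengthening the furan side chain from isopropyl to pentan-3-yl

This account rests on a few compounds, and the source may have more. Where it says the series, first, only, none or still open, it means among the compounds named here.

Measured in an assay on CHO cells for displacement of a labelled ligand from C-X-C chemokine receptor type 1 (Homo sapiens); on this read-out lower numbers stand for stronger inhibition and higher numbers for weaker inhibition:
compound 1, `CC[C@@H](Nc1c(Nc2cccc(C(=O)N(C)C)c2O)c(=O)c1=O)c1ccc(C)s1`, 146 nM
compound 2, `CC[C@@H](Nc1c(Nc2cccc(C(=O)N(C)C)c2O)c(=O)c1=O)c1cc(C(C)C)co1`, 3 nM

Among the compounds with values here, compound 2 has the lower of the two numbers measured so far; its only neighbour is compound 1, and the step of a 49-fold lower number from compound 1 to compound 2 (1.69 log units; beyond the scatter) separates them. Within the data shown here, that step exchanges one five-membered ring for another and is the single measured step available.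

Compound 3, `CCC(CC)c1coc([C@@H](CC)Nc2c(Nc3cccc(C(=O)N(C)C)c3O)c(=O)c2=O)c1`, keeps the shared core and the furan of compound 2 and changes only the small side chain on it: pentan-3-yl in place of isopropyl on an aromatic carbon. Among the measured compounds shown here, no measured step alters an alkyl group on this furan, so the one step from compound 1 to compound 2 does not bear directly on this change. Without such a precedent, the expectation for compound 3 is a step that stays within the scatter, a 1.3-fold higher number from compound 2 to compound 3 (0.12 log units; within the scatter). Compound 3 is therefore estimated at 4 nM, with a range from 1 nM to 15 nM.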

Compound 3, inhibition constant: 30 nM
For compound 3 the middle estimate is 7.5-fold (0.88 log units) below the measured one, and the stated range ends below it.
By their numbers in this assay, from the lowest: compound 2; then compound 3; then compound 1.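

In this assay, the alkyl group on this furan carbon clearly matters: pentan-3-yl in place of isopropyl gives a 10-fold higher number from compound 2 to compound 3 (1.00 log units; beyond the scatter), even though the change adds only carbon atoms. The furan series still keeps part of its lead over the methylthiophene, with the ring change together with the larger group giving a 4.9-fold lower number from compound 1 to compound 3 (0.69 log units; beyond the scatter). Nothing available explains why the number rises with this exchange.

Two alkyl groups on the furan cannot show whether the number climbs steadily with size or whether isopropyl is close to a best fit. On these data alone, how an ethyl group, a cyclopropyl ring or a short chain ending in an amine would read on this aromatic carbon remains open.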